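The source may report more compounds than this note shows. Statements on the series, on what has been measured and on what is new or still open speak of the compounds shown alone.

Three compounds from one series have been examined in a functional assay on HepG2 cells (Homo sapiens) for cytotoxicity, read by MTT assay, with a stated time of 24 h; a higher number here means a weaker inhibitor, a lower number a stronger inhibitor. Compound 1, `O=C1/C(=C/c2ccncc2)CN(S(=O)(=O)c2ccc(Cl)cc2)C/C1=C\c1ccccc1F`, gives 5300 nM in this assay. Compound 2, `O=C1/C(=C/c2ccncc2)CN(S(=O)(=O)c2ccc(Br)cc2)C/C1=C\c1ccccc1F`, differs from compound 1 by bromo in place of chloro on an aromatic carbon; in this assay compound 2 gives 9300 nM, and the step of a 1.8-fold higher number from compound 1 to compound 2 (0.24 log units; within the scatter). Compound 3, `O=C1/C(=C/c2ccncc2)CN(S(=O)(=O)c2ccc(Cl)cc2)C/C1=C\c1ccccc1C(F)(F)F`, gives 7190 nM in this assay, and the step of a 1.4-fold higher number from compound 1 to compound 3 (0.13 log units; within the scatter). None of the three steps among these compounds reaches beyond the scatter, so the three values are best read as one cluster rather than as a ranking.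

Compound 4, `O=C1/C(=C/c2ccncc2)CN(S(=O)(=O)c2ccc(Br)cc2)C/C1=C\c1ccccc1C(F)(F)F`, has not yet been measured in this assay. It differs from compound 3 by bromo in place of chloro on an aromatic carbon. This is the same change that separates compound 1 from compound 2, and it occurs twice among the compounds shown; the two places where it is made are described in the same words. The cores on which it is made differ by trifluoromethyl in place of fluoro on an aromatic carbon.

Because the step of a 1.8-fold higher number from compound 1 to compound 2 (0.24 log units; within the scatter) stayed within the scatter, compound 4 is expected to remain close to compound 3, with an expected step of a 1.5-fold higher number from compound 3 to compound 4 (0.16 log units; within the scatter). The estimate for compound 4 in this assay is 10500 nM. The expected range for compound 4 runs from 5500 nM to 20000 nM, reflecting the small and uncertain size of the earlier step and the scatter of the measurement.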

Compound 4, half-maximal inhibitory concentration: 14500 nM
Estimate against measurement, compound 4: 1.4-fold (0.14 log units) below, within the range that was stated.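

In this assay the bromo-for-chloro change on the core of compound 3 gives a 2.0-fold higher number from compound 3 to compound 4 (0.30 log units; within the scatter), and it sits close to the same change on the core of compound 1: the same change on two cores in this assay, a 1.8-fold higher number (0.24 log units; within the scatter) from compound 1 to compound 2 and a 2.0-fold higher number (0.30 log units; within the scatter) from compound 3 to compound 4, 1.1-fold (0.06 log units) apart, within the scatter of two such steps.

The trifluoromethyl-for-fluoro change, now seen on the bromo-bearing core, gives a 1.6-fold higher number from compound 2 to compound 4 (0.19 log units; within the scatter), and it likewise agrees with its earlier counterpart: the same change on two cores in this assay, a 1.4-fold higher number (0.13 log units; within the scatter) from compound 1 to compound 3 and a 1.6-fold higher number (0.19 log units; within the scatter) from compound 2 to compound 4, 1.1-fold (0.06 log units) apart, within the scatter of two such steps.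

Each change therefore carried from one core to the other with no difference that can be told apart from the scatter, but every step here lies within that scatter, so the agreement does not show that either change has a real effect of its own, and two cores are too few to support a rule for the series.

The compounds shown hold only chloro or bromo on the sulfonyl-bearing aromatic ring and only fluoro or trifluoromethyl on the other varied ring, which leaves open whether an amine or a carboxylic acid in place of the halogen would give a step beyond the scatter. On these data alone, it also remains open whether the two changes would carry over in the same way on a core bearing a nitrile in place of the trifluoromethyl.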